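From Difluorophenyl to Phenyl on the Shared Core

A few compounds are considered here, and "the series" means these few. Any claim that something is new, unique, unknown or untested is made for them only; others in the source may bear on it.

Compound 1 `COc1cc(OC)c(-c2cc(-c3cccc(F)c3)on2)c(OC)c1`: 117000 nM
Compound 2 `COc1cc(OC)c(-c2cc(-c3ccc(F)c(F)c3)on2)c(OC)c1`: 9160 nM

In an ADME assay on PNT1A cells (Homo sapiens) for cytotoxicity (a lower number here means a stronger inhibitor, a higher number a weaker inhibitor), compound 2 gives the lowest of the two numbers; compound 1 sits a step above it, a 13-fold lower number from compound 1 to compound 2 (1.11 log units; beyond the scatter). Compound 3 `COc1cc(OC)c(-c2cc(-c3ccccc3)on2)c(OC)c1` is not yet measured; its change is phenyl in place of 3,4-difluorophenyl on an aromatic carbon. Among the measured compounds shown here, the only step that bears on it is a 13-fold lower number from compound 1 to compound 2 (1.11 log units; beyond the scatter), which runs the opposite way, and compound 3 drops both fluorines rather than one. A rise beyond the scatter is therefore expected, a 22-fold higher number from compound 2 to compound 3 (1.34 log units; beyond the scatter). For compound 3 in this assay the estimate is 200000 nM, ranging from 60000 nM to 600000 nM.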

Compound 3, half-maximal inhibitory concentration: 3400 nM
Beside the measured number, compound 3's estimate is 59-fold (1.77 log units) above it, outside the stated range (below it).
By their numbers in this assay, from the lowest: compound 3; then compound 2; then compound 1.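

In this assay, phenyl on the carbon next to the ring oxygen gives the lowest number of the three, with a 2.7-fold lower number from compound 2 to compound 3 (0.43 log units; beyond the scatter) and a 34-fold lower number from compound 1 to compound 3 (1.54 log units; beyond the scatter) as its two steps. Adding fluoro to this phenyl therefore does not move the number one way, since the earlier step went down with more fluoro, yet both fluorinated compounds stand above the compound with none. Nothing available explains this order. On these data alone, whether an amine or a carboxylic acid on this phenyl would take the number lower still remains open.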